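The source may report more compounds than this note shows. Statements on the series, on what has been measured and on what is new or still open speak of the compounds shown alone.

In a physicochemical assay for lipophilicity, at pH 7.4 (on this read-out lower numbers stand for lower lipophilicity and higher numbers for higher lipophilicity), compound 1 `CCCn1nc2c(=O)[nH]c(-c3cc(S(=O)(=O)N4CCN(C)CC4)cnc3OCCOC)nc2c1CC` gives 1 and compound 2 `CCc1c2nc(-c3cc(S(=O)(=O)N4CCN(CC)CC4)cnc3OCCOC)[nH]c(=O)c2nn1C(C)C` gives 1 at the digits shown, so compound 2 stands level with compound 1, within the scatter. Compound 3 `CCc1c2nc(-c3cc(S(=O)(=O)N4CCN(CC)CC4)cnc3OCCOC)[nH]c(=O)c2nn1CCOC` departs from compound 2 in one place (2-methoxyethyl in place of isopropyl on an aromatic nitrogen): 2-methoxyethyl in place of isopropyl on an aromatic nitrogen, next to the ring atom that bears an ethyl group. Among the compounds with values here, no measured pair differs in one place only, so this change has no direct precedent here and the expectation rests on the structural change alone. A modest step towards lower numbers in this assay is expected, a little beyond the scatter, though no real change cannot be excluded. The expected move is a number 0.40 log units lower from compound 2 to compound 3 (beyond the scatter) as estimated here. Compound 3 is expected at 0.6 on this read-out, with an estimated range from 0.1 to 1.1 for repeat measurements.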

Compound 3, distribution coefficient: 1.4
The estimate for compound 3 lay 0.80 log units below the measured number; the whole stated range lies below it.
By their numbers in this assay, from the lowest: compounds 1 and 2 (each within the scatter of the next); then compound 3.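

Replacing isopropyl with 2-methoxyethyl on the aromatic nitrogen, next to the ring atom that bears an ethyl group, gives in this assay a number 0.40 log units higher from compound 2 to compound 3 (beyond the scatter). Within the data shown here, this is the first single-place step: the read-out does respond to the group at this position, and the entering 2-methoxyethyl, with its oxygen and hydrogen-bond acceptor, does not bring the number down in this pair. Nothing measured in the series accounts for the direction of this step.

From the compounds shown here alone, one pair cannot separate the oxygen of the new chain from the change in chain shape, so it remains open how a butyl chain, 3-methoxypropyl or an amine such as 2-aminoethyl would read on the same nitrogen. Going by these compounds, whether the step carries over to the compound 1 side of the series also remains open.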